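One Added Methyl, Two Different Starting Points

The compounds below may be only part of what the source reports. "The series", "measured", "known", "first", "only" and "open" are said of these compounds alone.

Measured so far:
compound 1, `CCOC(=O)C1=C(C)N(C)C(=O)NC1c1ccsc1`, gives 53% in an assay on membranes from HEK293 cells for displacement of a labelled ligand from adenosine receptor A2b (Homo sapiens), read by scintillation counting, with a stated time of 30 min, tested at 1 uM; on this read-out lower numbers stand for less inhibition and higher numbers for more inhibition at the one concentration tested (going by the name of the read-out);
compound 2, `CCCOC(=O)C1=C(C)N(C)C(=O)NC1c1ccsc1`, gives 1%;
compound 3, `CCCC(=O)C1=C(C)NC(=O)NC1c1cccs1`, gives 9%.

Compounds 1 and 2 share one core and differ in a single place: methyl in place of hydrogen on a saturated chain carbon, two bonds along the chain from an oxygen next to a carbonyl group. That change gave a number 52 percentage points lower from compound 1 to compound 2 (beyond the scatter). Compound 3 carries a different core, and how its core differs from that of compound 1 is not broken down here, so only the two values can be set side by side: compound 3 gives a lower number than compound 1, while its number and that of compound 2 lie within the usual scatter of each other.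

Compound 4, `CC1=C(C(=O)CC(C)C)C(c2cccs2)NC(=O)N1`, has not yet been tested in this assay. It differs from compound 3 by methyl in place of hydrogen on a saturated chain carbon bound to two saturated chain carbons. Going by the values given here, this is the same kind of change as the one from compound 1 to compound 2, but not the same: the surroundings of the place differ. In the earlier pair the carbon lies two bonds along the chain from an oxygen next to a carbonyl group; here it is bound to two saturated chain carbons.

Whether the second change costs as much as the first cannot be read from a single earlier step. Compound 3 starts from a low number, which leaves little room for a drop of the earlier size. The step from compound 3 to compound 4 is therefore expected to be small, a number 4 percentage points lower from compound 3 to compound 4 (within the scatter). This rests on the low starting value of compound 3, 9%, and on the downward direction seen in a number 52 percentage points lower from compound 1 to compound 2 (beyond the scatter). Compound 4 is thus estimated to give 5%, most likely between -8% and 20%.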

Compound 4, a percentage reported as inhibition, at one concentration (the size of the read-out at that concentration, not a potency): 43%
Estimate against measurement, compound 4: 38 percentage points below, outside the stated range (above it).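

In this assay, going from propylcarbonyl to isobutylcarbonyl gave a number 34 percentage points higher from compound 3 to compound 4 (beyond the scatter). The same kind of change, methyl in place of hydrogen on a saturated chain carbon, therefore cannot be carried from one core to the other in this series as a fixed penalty, and here not even its direction carries over: the same change on two cores in this assay, a number 52 percentage points lower (beyond the scatter) from compound 1 to compound 2 and a number 34 percentage points higher (beyond the scatter) from compound 3 to compound 4, 86 percentage points apart, beyond the scatter of two such steps

What the two steps do not show is why they part ways: the cores differ and so do the surroundings of the carbon that takes the methyl, and this single pair of steps cannot separate those two differences or support a rule for the whole series.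

Still open, on these data alone, is what the same methyl change would do on a third core, where a further step could side with either of these two or with neither. Also open, as far as these compounds go, is whether a longer chain or an amine in place of the isobutyl end would hold the number near that of compound 4, 43%, or lose it again.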